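Swapping 5-carboxyfuran-2-yl for 5-carboxythiophen-2-yl on a shared core

A few compounds are considered here, and "the series" means these few. Any claim that something is new, unique, unknown or untested is made for them only; others in the source may bear on it.

Measured in a functional assay for inhibition, with Homo sapiens as the target; a lower number here means a stronger inhibitor, a higher number a weaker inhibitor:
Compound 1 `Nc1ccc(-c2csc(-c3cccnc3)n2)cc1` gives 3000 nM
Compound 2 `CCOc1ccc(-c2nc(-c3ccc(C(=O)O)o3)cs2)cc1OCC` gives 20 nM

For the measured compounds named here, of these two numbers, the one for compound 2 is the lower, and the gap to compound 1 lies well beyond the scatter. The two compounds differ in more than one place, so their values show only that gap and isolate no single change.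

Compound 3 `CCOc1ccc(-c2nc(-c3ccc(C(=O)O)s3)cs2)cc1OCC` is not yet measured. It departs from compound 2 at one place (5-carboxythiophen-2-yl in place of 5-carboxyfuran-2-yl on an aromatic carbon), with 5-carboxythiophen-2-yl in place of 5-carboxyfuran-2-yl on an aromatic carbon. Going by the values given here, no measured pair speaks directly to this exchange, so only a modest expectation is offered. The expected change (a 1.5-fold higher number from compound 2 to compound 3 (0.18 log units; within the scatter)) is slightly upward and not beyond the scatter. In this assay, compound 3 is estimated at 30 nM with an expected range from 8 nM to 120 nM for this measurement.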

Compound 3, half-maximal inhibitory concentration in the Homo sapiens assay: 80 nM
Compound 3: middle estimate off by 2.7-fold (0.43 log units), on the low side, and the stated range covers the measured number.
By their numbers in the Homo sapiens assay, from the lowest: compound 2; then compound 3; then compound 1.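

For the compounds shown here, in the Homo sapiens assay, the exchange of 5-carboxyfuran-2-yl for 5-carboxythiophen-2-yl is the first change that can be read on its own: compound 2 gives 20 nM and compound 3 gives 80 nM, and the exchange gives a 4.0-fold higher number from compound 2 to compound 3 (0.60 log units; beyond the scatter), so this position on an aromatic carbon is sensitive to the choice between the two rings even though the heavy atom count stays the same. In a physicochemical assay for solubility (on this read-out higher numbers stand for higher solubility and lower numbers for lower solubility), compound 2 gives 23000 ug/mL and compound 3 gives 23000 ug/mL, and the same exchange gives no change at the digits printed from compound 2 to compound 3 (within the scatter), so the two read-outs part ways for this pair. Nothing shown bears on the reason for either step.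

The compounds shown leave open how this position would respond if a primary amide or a tetrazole stood in place of the carboxylic acid. They also leave open whether the step between the two rings would persist with methoxy groups in place of the ethoxy groups.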